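Ether to Thioether Swap on a Shared Core

This account rests on a few compounds, and the source may have more. Where it says the series, first, only, none or still open, it means among the compounds named here.

Three compounds share one core and differ in the group attached to a single carbon of its fused ring system. Compound 1, `Nc1cc(N)c2nc(-c3ccccc3)c(Oc3ccc(Cl)c(Cl)c3)nc2c1`, carries a 3,4-dichlorophenoxy group. In a functional assay on CCRF-CEM cells (Homo sapiens) for inhibition, read by sulforhodamine B assay, with a stated time of 48 h (on this read-out higher numbers stand for weaker inhibition of growth and lower numbers for stronger inhibition of growth), compound 1 reaches only the assay limit of < 100000 nM, which is not a measured number. Compound 2, `Nc1cc(N)c2nc(-c3ccccc3)c(NCc3ccc(Cl)c(Cl)c3)nc2c1`, joins the same dichlorophenyl ring through a nitrogen-and-carbon link, and in this assay compound 2 gives 1820 nM. Compound 3, `CCOC(=O)[C@H](CCC(=O)O)NC(=O)c1ccc(Sc2nc3cc(N)cc(N)c3nc2-c2ccccc2)cc1`, joins the core through sulfur to a phenyl ring bearing a long amide-ester tail. In this assay compound 3 also stops at the limit of < 100000 nM. Where compound 1 stands is thus a ceiling, not a value: the limit of < 100000 nM in this assay, at which 2 of the 3 values shown sit.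

Compound 4, `Nc1cc(N)c2nc(-c3ccccc3)c(Sc3ccc(Cl)c(Cl)c3)nc2c1`, is not yet measured. It differs from compound 1 in one place: (3,4-dichlorophenyl)sulfanyl in place of 3,4-dichlorophenoxy on an aromatic carbon. Among the measured compounds, the oxygen-linked compound 1 and the sulfur-linked compound 3 both sit at the limit, while only compound 2 returns a number. A sulfur link to the same dichlorophenyl ring is expected to stay near the weak end, so the step that the limit leaves unreadable from compound 1 to compound 4 is expected to be small or none beyond the scatter. Compound 4 is therefore estimated at 30000 nM, within a range from 5000 nM to 100000 nM.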

Compound 4, concentration for total growth inhibition: < 100000 nM
Compound 4: only a limit was reported; the forecaster's own chance of this, stated with the estimate: 45%; the middle value does not contradict the limit.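

In this assay compound 4 gives < 100000 nM as a limit of the assay and not a number. Among the compounds shown here, compound 1 also rests at a limit, so no step between compound 1 and compound 4 can be read: the limit of < 100000 nM in this assay, at which 3 of the 4 values shown sit.

The compounds shown leave open whether the sulfur link of compound 4 and the oxygen link of compound 1 differ at all in growth inhibition.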